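This account rests on a few compounds, and the source may have more. Where it says the series, first, only, none or still open, it means among the compounds named here.

Compound 1 `COc1cc(CNC(=O)CCCCCCC(C)C)ccc1OCCCCOc1ccc(-c2cc(=S)ss2)cc1` stands in a functional assay on K562 cells (Homo sapiens) for antiproliferative activity, read by MTT assay, with a stated time of 48 h (a lower number here means a stronger inhibitor, a higher number a weaker inhibitor), at a limit of the assay, > 50000 nM, and not at a number. Compound 2 `COc1cc(CNC(=O)CCCC/C=C/C(C)C)ccc1OC(=O)CCC(=O)Oc1ccc(C(N)=S)cc1` returns only the limit > 50000 nM in this assay. Compound 3 `COc1cc(CNC(=O)CCCC/C=C/C(C)C)ccc1OCCCCCOc1ccc(-c2cc(=S)ss2)cc1` likewise gives only the limit > 50000 nM in this assay. All three values sit at the limit of > 50000 nM in this assay, at which 3 of the 3 values shown sit, so compound 1 cannot be ordered against the other two; the values show only that none of them reached a number. Compound 4 `COc1cc(CNC(=O)CCCC/C=C/C(C)C)ccc1OCCCCOc1ccc(-c2cc(=S)ss2)cc1` differs from compound 1 by 3-methylbut-1-en-1-yl in place of isopentyl on a saturated chain carbon, four bonds along the chain from a carbonyl carbon. Within the data shown here, with no measured step, no change beyond the scatter is expected in this assay in either direction, and the step expected, a step that the limit leaves unreadable from compound 1 to compound 4, is small. Compound 4 is expected in this assay to give 60000 nM, within 20000 nM to 200000 nM, most probably again as a limit only.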

Compound 4, half-maximal inhibitory concentration: > 50000 nM
Compound 4 gave a limit, no number (the forecaster's own chance of this, stated with the estimate: 85%); the middle value lies beyond the limit too.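

No step can be read from compound 1 to compound 4, since both stop at a limit: the limit of > 50000 nM in this assay, at which 4 of the 4 values shown sit. The compounds shown leave open whether any change to the shared core would give a number in this assay.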